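The source may report more compounds than this note shows. Statements on the series, on what has been measured and on what is new or still open speak of the compounds shown alone.

Measured so far in an ADME assay on HUVEC cells (Homo sapiens) for inhibition, read by MTT assay, with a stated time of 48 h; a higher number here means a weaker inhibitor, a lower number a stronger inhibitor:

Compound 1 `COc1cc(/C=N/Nc2nc(-c3ccc(C(F)(F)F)cc3)cs2)c(Br)c(Br)c1OC` gives > 100000 nM, which is a limit of the assay rather than a number.
Compound 2 `Fc1ccc(/C=N/Nc2nc(-c3cccc(Br)c3)cs2)cc1F` gives > 100000 nM, again only a limit.

Compound 1 therefore stands at the assay limit, not at a measured number; both values shown so far sit there (the limit of > 100000 nM in this assay, at which 2 of the 2 values shown sit). Compound 3 `COc1cc(/C=N/Nc2nc(-c3cccc(Br)c3)cs2)c(Br)c(Br)c1OC` is the next compound to be run. It differs from compound 1 by 3-bromophenyl in place of 4-(trifluoromethyl)phenyl on an aromatic carbon. Going by the values given here, no step between measured compounds is available to calibrate this change. Compound 2 already carries the 3-bromophenyl group and also sits at the limit. In this assay no step beyond the scatter is expected, and compound 3 will most likely be reported as a limit too. The expected value for compound 3 is 150000 nM, range 50000 nM to 500000 nM. The estimated step is a step that the limit leaves unreadable from compound 1 to compound 3.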

Compound 3, half-maximal inhibitory concentration: > 100000 nM
Compound 3: only a limit was reported; the forecaster's own chance of this, stated with the estimate: 85%; the middle value does not contradict the limit.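

In this assay, going by these compounds alone, compound 3 gives > 100000 nM, a limit and not a number, so no step from compound 1 to compound 3 can be read. The compounds shown leave open whether 3-bromophenyl in place of 4-(trifluoromethyl)phenyl changes inhibition at all, as compound 1, compound 2 and compound 3 all stand at the limit.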